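The compounds below may be only part of what the source reports. "The series", "measured", "known", "first", "only" and "open" are said of these compounds alone.

Measured compounds:
Compound 1, `C=C(Br)C(=O)Nc1ccc(/C=C/C(=O)c2ccc(F)cc2)cc1`, gives 660 nM.
Compound 2, `C=C(Br)C(=O)Nc1ccc(/C=C/C(=O)c2ccc(Cl)cc2)cc1`, gives 810 nM.
Compound 3, `C=C(Br)C(=O)Nc1ccc(/C=C/C(=O)c2ccc(Br)cc2)cc1`, gives 680 nM.

All three were tested in a functional assay on MOLT-4 cells (Homo sapiens) for antiproliferative activity, with a stated time of 48 h; on this read-out higher numbers stand for weaker inhibition and lower numbers for stronger inhibition. Compound 3 stands second highest of the three numbers, but its steps to both neighbours are within the scatter: a 1.2-fold lower number from compound 2 to compound 3 (0.08 log units; within the scatter) and a 1.0-fold higher number from compound 1 to compound 3 (0.01 log units; within the scatter). The three halogens on the aromatic carbon therefore give numbers that cannot be told apart, as a 1.2-fold higher number from compound 1 to compound 2 (0.09 log units; within the scatter) also shows.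

Compound 4, `C=C(Br)C(=O)Nc1ccc(/C=C/C(=O)c2cccc(OC)c2)cc1`, is not yet measured. It differs from compound 3 in one place: 3-methoxyphenyl in place of 4-bromophenyl on a carbonyl carbon. The measured steps all concern one halogen in place of another on the same aromatic carbon, and none of them reaches beyond the scatter. Among the compounds with values here, they bear on compound 4 only loosely, since a methoxy group on a different ring position has no counterpart among the measured compounds. Within the data shown here, with no step in the set rising above the scatter, no step beyond the scatter is expected here either, in either direction.

For compound 4 the expected value in this assay is 700 nM, with a range from 300 nM to 1600 nM, so that the expected step is a 1.0-fold higher number from compound 3 to compound 4 (0.01 log units; within the scatter).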

Compound 4, half-maximal inhibitory concentration: 850 nM
Compound 4: the middle estimate sits 1.2-fold (0.08 log units) below what was measured; measured number inside the range.
By their numbers in this assay, from the lowest: compounds 1, 3, 2 and 4 (each within the scatter of the next).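

The earlier steps shown here only replaced one halogen with another on the same aromatic carbon, whereas this step replaces the whole group on the carbonyl carbon: 4-bromophenyl leaves and 3-methoxyphenyl enters, bringing oxygen and a hydrogen-bond acceptor that the halogen compounds lack. Even so, this assay shows a 1.3-fold higher number from compound 3 to compound 4 (0.10 log units; within the scatter) and a 1.0-fold higher number from compound 2 to compound 4 (0.02 log units; within the scatter) and a 1.3-fold higher number from compound 1 to compound 4 (0.11 log units; within the scatter) so all four numbers stay within the usual scatter of one another, and this position tolerates a larger change than the halogen series alone could show. Nothing measured here accounts for how closely these numbers agree.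

As far as these compounds go, whether an amine or a carboxylic acid in place of the methoxy group would give a step beyond the scatter remains open, and so does the effect of a longer chain there. All four compounds also share the same core, so what a change elsewhere in that core would do to the number in this assay is not answered by these compounds.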